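Working notes: compound 3 before measurement

The compounds below may be only part of what the source reports. "The series", "measured", "known", "first", "only" and "open" are said of these compounds alone.

Measured so far:
compound 1 `CN(Cc1nc2cc(C(F)(F)F)ccc2nc1-c1ccccc1)c1ccc(F)cc1` — 5000 nM
compound 2 `Cc1ccc(N(C)Cc2nc3cc(C(F)(F)F)ccc3nc2-c2ccccc2)cc1` — 11000 nM

The read-out throughout is an assay on isolated protein for inhibition of Dihydrofolate reductase (Homo sapiens), read by spectrophotometry; on this read-out higher numbers stand for weaker inhibition and lower numbers for stronger inhibition. Among the two measured compounds, compound 2 stands with the highest number, 11000 nM; its nearest neighbour is compound 1, and the single measured step, a 2.2-fold higher number from compound 1 to compound 2 (0.34 log units; beyond the scatter), separates the two.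

Compound 3 `CCN(Cc1nc2cc(C(F)(F)F)ccc2nc1-c1ccccc1)c1ccc(C)cc1` differs from compound 2 by methyl in place of hydrogen on a saturated chain carbon bound to a nitrogen on an aromatic ring; the same difference read one bond further out is methyl to ethyl, methyl(4-methylphenyl)amino to ethyl(4-methylphenyl)amino. Among the measured compounds shown here, the only measured step, a 2.2-fold higher number from compound 1 to compound 2 (0.34 log units; beyond the scatter), concerns a substituent on an aromatic carbon and not the saturated chain carbon bound to the nitrogen; no measured pair changes the group on that carbon. For the measured compounds named here, the data therefore give no direction for a step in this assay, and no step beyond the scatter is expected from this change. Compound 3 is estimated at 11000 nM, with a range from 4000 nM to 30000 nM. The step this estimate implies, no change at the digits printed from compound 2 to compound 3 (within the scatter), is expected to stay within the scatter.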

Compound 3, inhibition constant: 4000 nM
The estimate for compound 3 lay 2.8-fold (0.44 log units) above the measured number, and the stated range covers the measured number.
By their numbers in this assay, from the lowest: compounds 3 and 1 (each within the scatter of the next); then compound 2.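

In this assay, the saturated chain carbon bound to the nitrogen on an aromatic ring proves sensitive to substitution: methyl in place of hydrogen there, which turns methyl(4-methylphenyl)amino into ethyl(4-methylphenyl)amino, gives a 2.8-fold lower number from compound 2 to compound 3 (0.44 log units; beyond the scatter). Among the compounds shown here, this is the first measured change at that carbon, and its direction is opposite to that of the earlier change on the aromatic carbon, a 2.2-fold higher number from compound 1 to compound 2 (0.34 log units; beyond the scatter), so the higher number seen with methyl in place of fluoro is offset once ethyl is present. The overall comparison, a 1.3-fold lower number from compound 1 to compound 3 (0.10 log units; within the scatter), leaves ethyl(4-methylphenyl)amino and (4-fluorophenyl)(methyl)amino indistinguishable on this read-out, and no measurement at hand accounts for the step at the chain carbon.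

Going by these compounds, whether a longer chain on that nitrogen, such as propyl, or a chain ending in a hydroxyl group would continue the direction seen from methyl to ethyl remains open. Also open, on these data alone, is whether ethyl gives a step of similar size when the aromatic ring carries fluoro instead of methyl, as a single pair cannot show whether the two changes act independently.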